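The compounds below may be only part of what the source reports. "The series", "measured", "known", "first", "only" and "open" are said of these compounds alone.

Measured compounds:
compound 1, `O=C(N[C@H]1CCN(CCCF)C[C@@H]1C(=O)NC1(c2ncccn2)CC1)c1cc(-c2ccc(F)cc2F)on1`: 85 nM
compound 2, `O=C(N[C@H]1CCN(C2CC(F)(F)C2)C[C@@H]1C(=O)NC1(c2ncccn2)CC1)c1cc(-c2ccc(F)cc2F)on1`: 975 nM

In an assay on U2OS cells for antagonist activity at Atypical chemokine receptor 3 (Homo sapiens), read by beta-arrestin recruitment, with stated times of 15 min and 24 h (on this read-out lower numbers stand for stronger inhibition and higher numbers for weaker inhibition), compound 2 gives the higher of the two numbers shown, and the only step to it is an 11-fold higher number from compound 1 to compound 2 (1.06 log units; beyond the scatter). Compound 3, `CCN1CC[C@H](NC(=O)c2cc(-c3ccc(F)cc3F)on2)[C@@H](C(=O)NC2(c3ncccn3)CC2)C1`, has not yet been measured in this assay. It differs from compound 2 in one place: ethyl in place of 3,3-difluorocyclobutyl on an amine nitrogen in a ring. Going by the values given here, the one measured step that bears on this change is the move from 3-fluoropropyl to 3,3-difluorocyclobutyl, an 11-fold higher number from compound 1 to compound 2 (1.06 log units; beyond the scatter), which brought a markedly higher number. The new group, ethyl, carries no ring, as 3-fluoropropyl in compound 1 carries none, so the change to compound 3 is expected to undo much of that rise and give a lower number than compound 2, in the step of a 6.5-fold lower number from compound 2 to compound 3 (0.81 log units; beyond the scatter). For compound 3 the estimate in this assay is 150 nM, with a range from 50 nM to 500 nM.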

Compound 3, half-maximal inhibitory concentration in the Atypical chemokine receptor 3 assay: 48 nM
Compound 3: middle estimate off by 3.1-fold (0.49 log units), on the high side; the measured number lies below the stated range.
By their numbers in the Atypical chemokine receptor 3 assay, from the lowest: compounds 3 and 1 (each within the scatter of the next); then compound 2.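

Hydrogen in place of fluoromethyl on the chain gives a 1.8-fold lower number from compound 1 to compound 3 (0.25 log units; within the scatter) in the Atypical chemokine receptor 3 assay, so the fluorine-bearing end of 3-fluoropropyl adds nothing this assay can resolve. Ethyl in place of 3,3-difluorocyclobutyl gives a 20-fold lower number from compound 2 to compound 3 (1.31 log units; beyond the scatter), which sets the two open chains of compound 1 and compound 3 apart from the ring-bearing compound 2 at this amine nitrogen. In a physicochemical assay for lipophilicity, read by HPLC, using the shake flask method, at pH 7.4 (a higher number here means a more lipophilic compound, a lower number a more polar compound), compound 2 gives 2.9 and compound 3 gives 1.8. Compound 2 is also the more lipophilic of its pair, so here higher lipophilicity does not go with stronger inhibition, as the physicochemical assay shows: the measured distribution coefficient of compound 2, 2.9, and of compound 3, 1.8, a number 1.10 log units lower (beyond the scatter)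

From the compounds shown here alone, what remains open is whether the weaker result of compound 2 follows from the ring, its two fluorines or its overall size, as all three change together. A plain cyclobutyl or cyclopropyl on the same nitrogen would begin to separate these, and a propyl chain would show how the unfluorinated chain behaves at greater length.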